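Adding fluoro to the aryl ring of compound 3

The compounds below may be only part of what the source reports. "The series", "measured", "known", "first", "only" and "open" are said of these compounds alone.

Values in a functional assay on BaF3 cells (Mus musculus) for antiproliferative activity, with a stated time of 48 h (a lower number here means a stronger inhibitor, a higher number a weaker inhibitor), are as follows:
Compound 1 (`CC(=O)N1CCN([C@H]2C[C@@H](n3cc(-c4ccc(Cl)c(O)c4)c4c(N)ncnc43)C2)CC1`): (3700 nM)
Compound 2 (`COc1cc(-c2cn([C@H]3C[C@@H](N4CCN(C(C)=O)CC4)C3)c3ncnc(N)c23)ccc1Cl`): (> 10000 nM), a limit
Compound 3 (`COC(=O)NC12CCC(n3cc(-c4ccc(Cl)c(N)c4)c4c(N)ncnc43)(CC1)CC2`): (2600 nM)

In this assay compound 3 at (2600 nM) lies within the scatter of compound 1 at (3700 nM) and the two cannot be told apart. Compound 2 gives only a limit (> 10000 nM) and no number.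

Compound 4 (`COC(=O)NC12CCC(n3cc(-c4cc(N)c(Cl)cc4F)c4c(N)ncnc43)(CC1)CC2`) differs from compound 3 by fluoro in place of hydrogen on an aromatic carbon, which turns 3-amino-4-chlorophenyl into 5-amino-4-chloro-2-fluorophenyl. For the measured compounds named here, the only measured step (an at least 2.7-fold higher number from compound 1 to compound 2 (0.43 log units; beyond the scatter)) is methyl in place of hydrogen on an oxygen on an aromatic ring, a different change that does not bear on this one. No step beyond the scatter is therefore expected in this assay, and the expected step is small (a 1.3-fold lower number from compound 3 to compound 4 (0.11 log units; within the scatter)). For compound 4 the estimated value is 2000 nM with an expected range from 400 nM to 8000 nM in this assay.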

Compound 4, half-maximal inhibitory concentration: 4100 nM
The estimate for compound 4 lay 2.1-fold (0.31 log units) below the measured number, and the stated range covers the measured number.
By their numbers in this assay, from the lowest: compounds 3, 1 and 4 (each within the scatter of the next). At a limit, above all of these: compound 2.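

In this assay, fluoro on this aromatic carbon, ortho to a large group and para to an amino group, gives a 1.6-fold higher number from compound 3 to compound 4 (0.20 log units; within the scatter) and so leaves the number indistinguishable from that of compound 3. This position on the 3-amino-4-chlorophenyl ring therefore accepts this single atom without a change that can be told from scatter. Nothing measured here bears on the cause of this step.

As far as these compounds go, whether a larger group on the same carbon, such as methoxy or a nitrile, would also stay within the scatter remains open.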